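The source may report more compounds than this note shows. Statements on the series, on what has been measured and on what is new or still open speak of the compounds shown alone.

In a functional assay on RAW264.7 cells (Mus musculus), read by Griess assay, with a stated time of 15 min (on this read-out higher numbers stand for weaker inhibition and lower numbers for stronger inhibition), compound 1 `C[C@@H]1C[C@H](O)C2=C(CO)C(=O)O/C2=C/[C@@]2(C)CC[C@]1(O)O2` gives 24700 nM and compound 2 `CO[C@]12CC[C@](C)(/C=C3/OC(=O)C(CO)=C3[C@@H](O)C[C@H]1C)O2` gives 28100 nM as its value, so compound 2 stands level with compound 1. Going by the values given here, the one measured step is a 1.1-fold higher number from compound 1 to compound 2 (0.06 log units; within the scatter) for methyl in place of hydrogen on an oxygen on a saturated carbon. Compound 3 `C/C=C(\C)C(=O)O[C@H]1C[C@@H](C)[C@]2(OC)CC[C@](C)(/C=C3/OC(=O)C(CO)=C31)O2` keeps the core of compound 2 but differs by a much larger change: (1-methylprop-1-en-1-yl)carbonyl in place of hydrogen on an oxygen on a saturated carbon on the hydroxy group that compound 2 still carries. Among the compounds with values here, the methyl step is the only guide, and it involves a far smaller group, so it says little here. Within the data shown here, no measured compound carries this new group, which leaves any forecast uncertain. In this assay a moderate move towards stronger inhibition is tentatively expected, with a 2.0-fold lower number from compound 2 to compound 3 (0.30 log units; within the scatter) as the estimated step, and no change at all remains possible. For compound 3 the estimate is 14000 nM with an expected range of 4000 nM to 40000 nM around it.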

Compound 3, half-maximal inhibitory concentration: 2400 nM
For compound 3 the middle estimate is 5.8-fold (0.77 log units) above the measured one, outside the stated range (below it).
By their numbers in this assay, from the lowest: compound 3; then compounds 1 and 2 (each within the scatter of the next).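

Replacing hydroxy with ((1-methylprop-1-en-1-yl)carbonyl)oxy on the shared core gives, in this assay, a 12-fold lower number from compound 2 to compound 3 (1.07 log units; beyond the scatter), which shows that inhibition at this position responds strongly to this change. The earlier methyl step, a 1.1-fold higher number from compound 1 to compound 2 (0.06 log units; within the scatter), sat on a different oxygen and stayed within the scatter, so it gave no sign of this. Nothing shown here explains the size of the new step.

Going by these compounds, it remains open whether the stronger inhibition needs this whole group or only its carbonyl: an acetyl group or a saturated butanoyl group at the same oxygen would help separate the two. On these data alone, it is also open whether the same group would give a step of similar size on compound 1, which lacks the methyl present on compound 2.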